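Compound 3 to compound 4: azetidin-1-yl to cyclohexylamino

The source may hold more compounds than are shown below. What is called first, only, known or untested is meant among the compounds shown, and "the series" means these compounds.

In a functional assay on HeLa cells (Homo sapiens) for inhibition, read by sulforhodamine B assay (a higher number here means a weaker inhibitor, a lower number a stronger inhibitor), compound 3 (`O=C1C(N2CCC2)=CC(=O)c2c1nc1n2[C@H]2OC[C@@H](O)[C@H]2OC1`) has no number, only the limit > 16000 nM of the assay. In this assay compound 1 (`Cc1ccc(NC2=CC(=O)c3c(nc4n3[C@H]3OC[C@@H](O)[C@H]3OC4)C2=O)cc1C`) gives 4320 nM and compound 2 (`O=C1C(Nc2ccc(C(F)(F)F)cc2)=CC(=O)c2c1nc1n2[C@H]2OC[C@@H](O)[C@H]2OC1`) gives 8920 nM as measured numbers.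

Compound 4 (`O=C1C(NC2CCCCC2)=CC(=O)c2c1nc1n2[C@H]2OC[C@@H](O)[C@H]2OC1`) is not yet measured. It has cyclohexylamino in place of azetidin-1-yl on a double-bonded ring carbon.

Among the measured compounds shown here, two measured steps bear on this change. Putting 4-(trifluoromethyl)phenyl in place of 3,4-dimethylphenyl on the amine nitrogen costs little (a 2.1-fold higher number from compound 1 to compound 2 (0.31 log units; beyond the scatter)). Putting azetidin-1-yl in place of (3,4-dimethylphenyl)amino costs at least as much, and its true size is hidden by the limit (an at least 3.7-fold higher number from compound 1 to compound 3 (0.56 log units; beyond the scatter)). For the measured compounds named here, compound 4 again has a ring on an amino nitrogen with its hydrogen, as compound 1 and compound 2 do, but that ring is not aromatic, and no such compound has been measured. Only part of the loss from compound 1 (an at least 3.7-fold higher number from compound 1 to compound 3 (0.56 log units; beyond the scatter)) is therefore expected to return, and compound 4 could still end at the limit. The expected change is a modest fall in the number (an at least 1.7-fold lower number from compound 3 to compound 4 (0.24 log units; that floor lies within the scatter)). For compound 4 the estimated value is about 9000 nM with an expected range from 3500 nM to 22000 nM on repeat measurement.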

Compound 4, half-maximal inhibitory concentration: > 16000 nM
Compound 4 gave a limit, no number (the forecaster's own chance of this, stated with the estimate: 25%); middle value at least 1.7-fold (0.24 log units) from the limit.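

In this assay compound 4 gives only a limit, > 16000 nM, and no number. An amino hydrogen on a ring is therefore not enough at this double-bonded ring carbon: with cyclohexyl on the amine nitrogen the series shows an at least 3.7-fold higher number from compound 1 to compound 4 (0.56 log units; beyond the scatter) and an at least 1.7-fold higher number from compound 2 to compound 4 (0.25 log units; that floor lies within the scatter), so among the four compounds shown, only the two with a substituted phenyl on that nitrogen, compound 1 and compound 2, reach measured values, and neither compound 3 nor compound 4 goes against this. The step between compound 3 and compound 4 cannot be read, and azetidin-1-yl and cyclohexylamino cannot be ranked against each other: the limit of > 16000 nM in this assay, at which 2 of the 4 values shown sit.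

Open, from the compounds shown here alone, is whether benzylamino, or a straight butyl chain on the amine nitrogen, would give a measured number in this assay or stay at the limit. Also open, going by these compounds, is how the value moves with other groups on the phenyl ring, such as methoxy or a carboxylic acid, and whether unsubstituted phenylamino alone holds the activity seen for compound 1 and compound 2.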